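The compounds below may be only part of what the source reports. "The series", "measured", "known", "first", "only" and "open" are said of these compounds alone.

Measured compounds and their half-lives:
compound 1 `Cc1cc(Cl)c2[nH]cc(-c3ccc4ccccc4n3)c2c1` — 0.3 h
compound 2 `Cc1cccc2c(-c3ccc4c(F)cccc4n3)c[nH]c12` — 0.217 h
compound 3 `Cc1cccc2c(-c3ccc4cccc(F)c4n3)c[nH]c12` — 0.983 h

In an ADME assay on microsomes from liver (Homo sapiens) for metabolic stability, using NADPH, with a stated time of 40 min, tested at 2 uM (a higher number here means that the compound lasts longer, a lower number that the compound disappears faster), compound 3 gives 0.983 h, the highest of the three numbers. The nearest is compound 1 with 0.3 h, a gap beyond the scatter; the furthest is compound 2 with 0.217 h, also a gap beyond the scatter. For the measured compounds named here, compounds 1 and 2 each differ from compound 3 in more than one place, so no single-point step is available among the measured set, and nothing measured shows what one halogen swap does in this assay.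

Compound 4 `Cc1cccc2c(-c3ccc4cccc(Br)c4n3)c[nH]c12` is not yet measured. Compared with compound 3, the difference is bromo in place of fluoro on an aromatic carbon of a six-membered aromatic ring of carbon only, part of a fused or bridged system of two rings. Going by the values given here, with no measured step of this kind to lean on, the step from compound 3 to compound 4 in this assay is expected to be small, plausibly within the scatter, with a slight lean toward a lower number. The estimate for compound 4 in this assay is 0.7 h, with a range from 0.3 h to 1.5 h, which means an expected step of a 1.4-fold lower number from compound 3 to compound 4 (0.15 log units; within the scatter).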

Compound 4, half-life: 2.4 h
Beside the measured number, compound 4's estimate is 3.4-fold (0.54 log units) below it; the whole stated range lies below it.
By their numbers in this assay, from the lowest: compounds 2 and 1 (each within the scatter of the next); then compound 3; then compound 4.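

In this assay the series now holds a comparison of two compounds that differ in one place, and bromo in place of fluoro on an aromatic carbon gives a 2.4-fold higher number from compound 3 to compound 4 (0.39 log units; beyond the scatter) with nothing else in the structure changed. The half-life therefore depends on which halogen sits at this carbon, ortho to a fused ring and meta to a fused ring, and the heavier halogen is at least compatible with a longer-lasting compound on this shared core, though this rests on a single pair and the step is modest. No measurement at hand bears on why the number moves with this swap.

The compounds shown leave open whether chloro, which appears only elsewhere on the core of compound 1, or a methoxy, a nitrile or an amine on this same carbon would carry the half-life further or bring it back. Also open, on these data alone, is whether bromo in place of fluoro at the carbon that bears fluoro in compound 2 would move the number the same way, so the step cannot yet be extended beyond this one position.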